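A few compounds are considered here, and "the series" means these few. Any claim that something is new, unique, unknown or untested is made for them only; others in the source may bear on it.

Measured compounds:
compound 1 `CCCCCCCCC(=O)N1c2ccccc2CCC1C(=O)Nc1ccccc1C(F)(F)F` gives 3350 nM;
compound 2 `O=C(Nc1ccccc1O)C1CCc2ccccc2N1` gives 5260 nM;
compound 3 `O=C(Nc1ccccc1O)C1CCc2ccccc2N1C(=O)c1ccccc1` gives 4210 nM.

Three compounds share a core and differ in what sits on the ring nitrogen and on the aniline ring. In a functional assay on MDA-MB-231 cells (Homo sapiens) for cytotoxicity, read by sulforhodamine B assay, with a stated time of 72 h (a higher number here means a weaker inhibitor of growth, a lower number a stronger inhibitor of growth), compound 3 stands second highest of the three numbers; it lies within the scatter of compound 2 on one side and of compound 1 on the other, so no order among the three can be claimed. For the measured compounds named here, the one single-point step that is known, a 1.2-fold lower number from compound 2 to compound 3 (0.10 log units; within the scatter), places benzoyl on the ring nitrogen and changes the number by less than the scatter.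

Compound 4 `CCCCCCCCC(=O)N1c2ccccc2CCC1C(=O)Nc1ccccc1O` is the next compound. It differs from compound 3 as follows: octyl in place of phenyl on a carbonyl carbon. Going by the values given here, no measured pair differs only by octyl against phenyl on a carbonyl carbon, so no step speaks to this change directly. Compound 1 carries the octylcarbonyl and compound 3 the benzoyl, but they also differ on the aniline ring; their two values lie within the scatter of each other. The known step within the scatter, and this pair of values, give no reason to expect a shift beyond the scatter, so the expected step is a 1.2-fold lower number from compound 3 to compound 4 (0.07 log units; within the scatter). Compound 4 is therefore estimated at 3600 nM, with a range from 1500 nM to 8500 nM.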

Compound 4, concentration for 50% growth inhibition: 54300 nM
Beside the measured number, compound 4's estimate is 15-fold (1.18 log units) below it; the measured number lies above the stated range.
By their numbers in this assay, from the lowest: compounds 1, 3 and 2 (each within the scatter of the next); then compound 4.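

In this assay the result shows that what the carbonyl carbon carries on the ring nitrogen can matter: octyl in place of phenyl gives a 13-fold higher number from compound 3 to compound 4 (1.11 log units; beyond the scatter) and octylcarbonyl in place of hydrogen gives a 10-fold higher number from compound 2 to compound 4 (1.01 log units; beyond the scatter) whereas benzoyl in place of hydrogen gave only a 1.2-fold lower number from compound 2 to compound 3 (0.10 log units; within the scatter) and stayed within the scatter. The octylcarbonyl group does not bring this rise wherever it stands, since hydroxy in place of trifluoromethyl on an aromatic carbon gives a 16-fold higher number from compound 1 to compound 4 (1.21 log units; beyond the scatter) so among these compounds the high number appears only where octylcarbonyl and hydroxy occur together, and the two places cannot be read as independent of each other. The data shown give no reason for this dependence.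

Going by these compounds, it remains open whether the rise follows the length of the chain, which a shorter acyl group such as acetyl or a longer chain on the same carbonyl carbon would test. On these data alone, it is also open how octylcarbonyl behaves with a methoxy group or an amine in place of hydroxy, and how benzoyl behaves with trifluoromethyl.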